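Swapping the Side Chain on a Shared Core

A few compounds are considered here, and "the series" means these few. Any claim that something is new, unique, unknown or untested is made for them only; others in the source may bear on it.

Measured compounds:
compound 1, `COc1ccc(N/C=N/C2=C(C#N)C3C(N4CCCC4)CCCCN3C(=O)N2c2ccccc2)cc1`: 37.2%
compound 2, `N#Cc1c2n(c(=O)n(-c3ccccc3)c1=N)CCCCC2N1CCCC1`: 88.7%
compound 3, `CCOC(=O)C(=O)NC1=C(C#N)C2C(N3CCCC3)CCCCN2C(=O)N1c1ccccc1`: 83.6%

All three compounds were tested in a functional assay on the whole organism (strain albino) for inhibition, with Rattus norvegicus as the target, read by paw edema, with stated times of 1 h and 2 h, at a dose of 20 mmol/kg by the intraperitoneal route; a higher number here means more inhibition at the dose given (going by the name of the read-out), a lower number less inhibition. Compound 3 stands second highest of the three numbers. Its nearest neighbour is compound 2, whose value lies within the scatter of repeated measurements, so the two cannot be told apart. Its furthest neighbour is compound 1, whose value lies well beyond the scatter below compound 3.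

Compound 4, `N#CC1=C(NCC(=O)N2CCCCC2)N(c2ccccc2)C(=O)N2CCCCC(N3CCCC3)C12`, differs from compound 3 in one place: ((piperidin-1-yl)carbonyl)methyl in place of (ethoxycarbonyl)carbonyl on an amine nitrogen

For the measured compounds named here, only one measured step touches this position: a number 46.4 percentage points higher from compound 1 to compound 3 (beyond the scatter). That step shows that what sits on this part of the core can move the read-out strongly. Going by the values given here, no measured step, however, compares the entering group with the leaving one, so the direction for compound 4 is open. Compound 2 carries no side chain here at all and still gives a high value, which suggests the core itself carries much of the effect.

Weighing both points, compound 4 is expected to show a number 15.6 percentage points lower from compound 3 to compound 4 (beyond the scatter) in this assay. The estimated value of compound 4 is 68%, with a range from 40% to 90%.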

Compound 4, a percentage reported as inhibition, in the whole organism at one dose (the size of the read-out at that dose, not a potency): 46.1%
Compound 4: the middle estimate sits 21.9 percentage points above what was measured; the measured number falls inside the stated range.
By their numbers in this assay, from the lowest: compounds 1 and 4 (each within the scatter of the next); then compounds 3 and 2 (each within the scatter of the next).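

The position on the amine nitrogen now has a direct comparison in this assay: ((piperidin-1-yl)carbonyl)methyl in place of (ethoxycarbonyl)carbonyl gives a number 37.5 percentage points lower from compound 3 to compound 4 (beyond the scatter), so the high number of compound 3 depends on what sits on this nitrogen and is not kept by every group placed there. The group of compound 4 has a non-aromatic ring, whereas the group of compound 1 has an aromatic one, yet the comparison gives a number 8.9 percentage points higher from compound 1 to compound 4 (within the scatter), so these two different groups cannot be told apart and an aromatic ring is not needed for the lower level. No measurement shown here bears on why this swap has so large an effect.

The swap changes several things at once, since the entering group has a methyl carbon on the nitrogen, a piperidine ring and no ethoxy group, so the compounds shown leave open which of these differences matters. An (ethoxycarbonyl)methyl group or a ((piperidin-1-yl)carbonyl)carbonyl group on the same amine nitrogen would separate these parts, each keeping one half of the group of compound 3.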